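Piperidine-to-piperazine swap at the aminopyrimidine position

The source may report more compounds than this note shows. Statements on the series, on what has been measured and on what is new or still open speak of the compounds shown alone.

Measured so far in an assay on A549 cells with Cystic fibrosis transmembrane conductance regulator variant F508del (Homo sapiens) as the target, read by fluorescence, with a stated time of 25 min; a lower number here means a smaller maximal response, a higher number a larger maximal response:
compound 1, `OC1CCCN(c2nc(-c3ccccn3)nc3c2CN(Cc2ccccc2)CC3)C1`, 30.6%
compound 2, `NC(=O)C1CCN(c2nc(-c3ccccn3)nc3c2CN(Cc2ccccc2)CC3)CC1`, 34.4%

Compound 2 and compound 1 lie within the usual scatter of each other, so neither is set apart on the numbers shown. Compound 3, `NC(=O)CN1CCN(c2nc(-c3ccccn3)nc3c2CN(Cc2ccccc2)CC3)CC1`, has not yet been measured in this assay. It differs from compound 2 by 4-(carbamoylmethyl)piperazin-1-yl in place of 4-carbamoylpiperidin-1-yl on an aromatic carbon. Within the data shown here, the one measured step that touches the same position is a number 3.8 percentage points higher from compound 1 to compound 2 (within the scatter), which stayed within the scatter. On that basis no step beyond the scatter is expected in this assay for compound 3. The estimated step is a number 1.4 percentage points lower from compound 2 to compound 3 (within the scatter). Compound 3 is estimated at 33%, with a range from 20% to 46%.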

Compound 3, largest response reached (Emax), in percent of the reference or control that the assay uses: "not active" (no number reported)
Nothing numeric was reported for compound 3, and the estimate cannot be compared.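

In this assay, among these compounds, compound 3 was reported as not active, without a number, so no step from compound 2 to compound 3 can be read. What lies behind this result stays open, and no data shown bear on it.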